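Replacing 3-Cyanophenyl with Methyl in Compound 4

The compounds below may be only part of what the source reports. "The series", "measured", "known", "first", "only" and "open" are said of these compounds alone.

Three measured compounds share one core and differ only in the group on a saturated chain carbon bound to an aromatic nitrogen. Compound 1 `Nc1nc(O)c2c(n1)n(C1OC(CO)[C@@H](O)[C@H]1O)c(=O)n2Cc1ccc(Cl)c(Cl)c1` carries a 3,4-dichlorophenyl there, and in a functional assay on the whole organism (B cells) with Mus musculus as the target (on this read-out lower numbers stand for smaller maximal responses and higher numbers for larger maximal responses), compound 1 reaches 55%. Compound 2 `CCOC(=O)Cn1c(=O)n(C2OC(CO)[C@@H](O)[C@H]2O)c2nc(N)nc(O)c21` carries an ethoxycarbonyl, and in this assay compound 2 reaches 86%. Compound 3 `N#Cc1cccc(Cn2c(=O)n(C3OC(CO)[C@@H](O)[C@H]3O)c3nc(N)nc(O)c32)c1` carries a 3-cyanophenyl, and in this assay compound 3 reaches 16%, the lowest of the three: the step of a number 39 percentage points lower from compound 1 to compound 3 (beyond the scatter) and the step of a number 70 percentage points lower from compound 2 to compound 3 (beyond the scatter) both lowered the maximal response beyond the usual scatter.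

Compound 4 `CCn1c(=O)n(C2OC(CO)[C@@H](O)[C@H]2O)c2nc(N)nc(O)c21` differs from compound 3 by methyl in place of 3-cyanophenyl on a saturated chain carbon bound to an aromatic nitrogen; read one bond further out, 3-cyanobenzyl becomes ethyl. Both measured steps that brought in 3-cyanophenyl lowered the response sharply, so taking it out again is expected to raise it. Within the data shown here, how far is uncertain, since no measured compound carries methyl at that place. A rise of about a number 44 percentage points higher from compound 3 to compound 4 (beyond the scatter) is expected. Compound 4 is therefore estimated at 60%, within a range from 35% to 90%.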

Compound 4, largest response reached (reported as maximal response), in percent of the reference or control that the assay uses: 82%
Beside the measured number, compound 4's estimate is 22 percentage points below it, within the range that was stated.
By their numbers in this assay, from the lowest: compound 3; then compound 1; then compounds 4 and 2 (each within the scatter of the next).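

In this assay, methyl in place of 3-cyanophenyl gives a number 66 percentage points higher from compound 3 to compound 4 (beyond the scatter), so a large maximal response at this position does not depend on an aromatic ring. Methyl and ethoxycarbonyl, neither of which carries a ring, give a number 4 percentage points lower from compound 2 to compound 4 (within the scatter), so these two groups cannot be told apart on this read-out. Methyl in place of 3,4-dichlorophenyl gives a number 27 percentage points higher from compound 1 to compound 4 (beyond the scatter), which places both ring-bearing compounds, compound 1 and compound 3, under both ring-free ones, compound 2 and compound 4, with no compound shown going against this.

From the compounds shown here alone, it remains open whether a longer chain such as propyl, a carboxylic acid or an amine at this place would hold the response, or where an unsubstituted phenyl would fall. No measurement is at hand that explains these steps.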